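Replacing 4-bromophenyl by 2,4-dichlorophenyl on a thiazolethione core

This account rests on a few compounds, and the source may have more. Where it says the series, first, only, none or still open, it means among the compounds named here.

Measured compounds:
compound 1 `COc1ccc(C(=O)CSC(=S)Nc2cc(OC)c(OC)c(OC)c2)cc1`, 29.9 ug/mL
compound 2 `COc1cc(N2C(=S)SCC2(O)c2ccc(Cl)cc2Cl)cc(OC)c1OC`, 16.9 ug/mL
compound 3 `COc1cc(-n2c(-c3ccc(Br)cc3)csc2=S)cc(OC)c1OC`, > 100 ug/mL

In a functional assay on T47D cells (Homo sapiens) for cytotoxicity, read by MTT assay, with a stated time of 48 h (a lower number here means a stronger inhibitor, a higher number a weaker inhibitor), compound 3 gives only a limit, > 100 ug/mL, and no number; this is the limit of > 100 ug/mL in this assay, at which 1 of the 3 values shown sits. Compound 1 gives 29.9 ug/mL in this assay, and compound 2 gives 16.9 ug/mL, both on different cores from compound 3. Compound 4 `COc1cc(-n2c(-c3ccc(Cl)cc3Cl)csc2=S)cc(OC)c1OC` differs from compound 3 by 2,4-dichlorophenyl in place of 4-bromophenyl on an aromatic carbon. Going by the values given here, no step between measured compounds on this core is known, so the size of this change is untested. Compound 4 is expected to stay near the limit, with an estimated step of an at least 1.2-fold lower number from compound 3 to compound 4 (0.09 log units; that floor lies within the scatter) that may not rise beyond the scatter. Compound 4 is estimated at 80 ug/mL, within 30 ug/mL to 200 ug/mL.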

Compound 4, half-maximal inhibitory concentration: 43.4 ug/mL
Compound 4: the middle estimate sits 1.8-fold (0.27 log units) above what was measured, and the stated range covers the measured number.
By their numbers in this assay, from the lowest: compounds 2, 1 and 4 (each within the scatter of the next, the first and the last beyond it). At a limit, above all of these: compound 3.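

With 2,4-dichlorophenyl in place of 4-bromophenyl on the aromatic carbon next to the ring nitrogen, the shared core moves off the limit in this assay, giving an at least 2.3-fold lower number from compound 3 to compound 4 (0.36 log units; beyond the scatter). Compounds 1 and 2, on other cores, could not show that this group alone changes the reading of this core. The step is only a floor, since compound 3 gives no number: the limit of > 100 ug/mL in this assay, at which 1 of the 4 values shown sits. As far as these compounds go, whether 4-chlorophenyl or 2-chlorophenyl alone would give a similar step stays open, as does how an aminophenyl or carboxyphenyl group would read here.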